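Ester and sugar-acetyl variation: antiproliferation notes

The source may report more compounds than this note shows. Statements on the series, on what has been measured and on what is new or still open speak of the compounds shown alone.

Measured so far:
compound 1, `C/C=C1/[C@H](O[C@@H]2O[C@H](COC(C)=O)[C@@H](OC(C)=O)[C@H](OC(C)=O)[C@H]2OC(C)=O)OC=C(C(=O)OC)[C@H]1CC(=O)OCCC`: 6600 nM
compound 2, `C#CCOC(=O)C[C@@H]1C(C(=O)OC)=CO[C@@H](O[C@@H]2O[C@H](CO)[C@@H](O)[C@H](O)[C@H]2O)/C1=C/C`: a limit only, > 15000 nM
compound 3, `C/C=C1/[C@H](O[C@@H]2O[C@H](COC(C)=O)[C@@H](OC(C)=O)[C@H](OC(C)=O)[C@H]2OC(C)=O)OC=C(C(=O)O)[C@H]1CC(=O)O`: a limit only, > 20000 nM

In a functional assay on SK-BR-3 cells (Homo sapiens) for antiproliferative activity, read by MTT assay, with a stated time of 72 h (a higher number here means a weaker inhibitor, a lower number a stronger inhibitor), compound 1 alone gives a number, 6600 nM. Compound 2 sits at a limit of the assay, (the limit of > 15000 nM in this assay, at which 1 of the 3 values shown sits). Compound 3 sits at a different limit of the same assay, (the limit of > 20000 nM in this assay, at which 1 of the 3 values shown sits). Going by the values given here, no two measured compounds differ in a single place, so no measured step exists; compound 2 therefore stands among the weak end of the three, known only as a limit, with compound 1 the one value that is a number.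

Compound 4, `C/C=C1/[C@H](O[C@@H]2O[C@H](CO)[C@@H](O)[C@H](O)[C@H]2O)OC=C(C(=O)OC)[C@H]1CC(=O)OCC`, is to be measured in this assay. It differs from compound 2 by methyl in place of ethynyl on a saturated chain carbon bound to an oxygen next to a carbonyl group, which one bond further out reads propargyloxycarbonyl to ethoxycarbonyl, with the free sugar hydroxyls kept. Compound 2 gives only a limit, > 15000 nM. From that limit compound 4 is expected to stay weak, with the step that the limit leaves unreadable from compound 2 to compound 4 expected to be none beyond the scatter. Compound 4 is thus estimated at 20000 nM, within 8000 nM to 50000 nM, with a fair chance that only a limit is reported.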

Compound 4, half-maximal inhibitory concentration: > 15000 nM
Compound 4: no number, only a limit; the forecaster's own chance of this, stated with the estimate: 60%; the middle value lies beyond the limit too.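

Compound 2 and compound 4 both stand only as limits, so the step between them, methyl in place of ethynyl, cannot be read. The compounds shown leave open how far propargyloxycarbonyl and ethoxycarbonyl differ with the free sugar hydroxyls kept.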